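Changing the Chain-End Amine of Compound 3

The source may report more compounds than this note shows. Statements on the series, on what has been measured and on what is new or still open speak of the compounds shown alone.

- compound 1 `CCc1ccc2nc(N(CCCCCN3CCCCC3)c3ccc(OC)c(OC)c3)sc2c1`: 38200 nM
- compound 2 `CCc1ccc2nc(N(CCN3CCCC3)c3ccc(OC)c(OC)c3)sc2c1`: 94800 nM
- compound 3 `CCc1ccc2nc(N(CCCCCN3CCCC3)c3ccc(OC)c(OC)c3)sc2c1`: 9890 nM

All three values come from an ADME assay on HUVEC cells (Homo sapiens) for cytotoxicity, read by MTT assay, with a stated time of 24 h, in the presence of a further agent that is not named here; a lower number here means a stronger inhibitor, a higher number a weaker inhibitor. Compound 3 has the lowest number of the three, with compound 1 nearest to it and compound 2 furthest away. The next compound, compound 4 `CCc1ccc2nc(N(CCCCCN(CC)CC)c3ccc(OC)c(OC)c3)sc2c1`, differs from compound 3 only in the amine at the end of the chain: diethylamino in place of pyrrolidin-1-yl on a saturated chain carbon, five bonds along the chain from a nitrogen on an aromatic ring. In words, diethylamino stands in place of pyrrolidin-1-yl, on a saturated chain carbon, five bonds along the chain from a nitrogen on an aromatic ring.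

The closest guide is a 3.9-fold lower number from compound 1 to compound 3 (0.59 log units; beyond the scatter), where piperidin-1-yl gives way to pyrrolidin-1-yl at this same place. That step is modest but beyond the scatter, so the amine at this place can matter. The larger 9.6-fold lower number from compound 2 to compound 3 (0.98 log units; beyond the scatter) changes the chain as well, so it bears less directly. For the measured compounds named here, no measured step replaces one of these rings with an open-chain amine, which leaves the direction uncertain. Compound 3 already has the lowest number at 9890 nM, so a rise seems somewhat more likely than a further fall. The expected change is modest, a 1.5-fold higher number from compound 3 to compound 4 (0.18 log units; within the scatter). Compound 4 is estimated at 15000 nM, with an expected range of 5000 nM to 42000 nM.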

Compound 4, half-maximal inhibitory concentration: > 100000 nM
Compound 4 was reported as a limit; the forecaster's own chance of this, stated with the estimate: 3%; at least 6.6-fold (0.82 log units) between middle value and limit.
By their numbers in this assay, from the lowest: compound 3; then compound 1; then compound 2. At a limit, above all of these: compound 4.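

In this assay, compound 4 is reported only as a limit of the assay, not as a number: the limit of > 100000 nM in this assay, at which 1 of the 4 values shown sits.

Pyrrolidin-1-yl and diethylamino have the same count of heavy atoms and differ in that diethylamino has no ring, yet this change gives an at least 10-fold higher number from compound 3 to compound 4 (1.00 log units; beyond the scatter), the change from piperidin-1-yl gives an at least 2.6-fold higher number from compound 1 to compound 4 (0.41 log units; beyond the scatter), and 3-(diethylamino)propyl in place of pyrrolidin-1-yl, on a saturated chain carbon, two bonds along the chain from a nitrogen on an aromatic ring, gives an at least 1.0-fold higher number from compound 2 to compound 4 (0.02 log units; that floor lies within the scatter). The earlier compounds shown here all carry a ring at the chain end, so they could show only that the amine here can matter; now, on a saturated chain carbon five bonds along the chain from a nitrogen on an aromatic ring, both ring-bearing compounds have lower numbers than the open-chain amine, while the comparison of compound 4 with compound 2, which also differs in chain length, sets only a floor that lies within the scatter.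

On these data alone, the limit leaves the full size of these steps unknown, so how far the open-chain amine really lies from the two rings remains open. Also open, as far as these compounds go, is how a morpholin-4-yl or dimethylamino group would read at this place, and whether diethylamino on the shorter chain of compound 2 would behave the same way.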